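A limit and one number guide compound 3

The source may report more compounds than this note shows. Statements on the series, on what has been measured and on what is new or still open speak of the compounds shown alone.

Compound 1 `COc1ccc(NC(=O)NCCNS(=O)(=O)c2ccc(-c3ccccc3OCc3ccccc3)s2)cc1`: > 20000 nM
Compound 2 `O=[N+]([O-])c1ccc(NC(=S)NCCNS(=O)(=O)c2ccc(-c3ccccc3OCc3ccccc3)s2)cc1`: 11300 nM

Among the compounds with values here, in a functional assay on RS4-11 cells (Homo sapiens) for inhibition, read by CCK-8 assay, with a stated time of 48 h (a lower number here means a stronger inhibitor, a higher number a weaker inhibitor), compound 2 gives 11300 nM, the only true number so far. Compound 1 reads > 20000 nM, which is a limit of the assay and not a number. Within the data shown here, only one measured step exists, an at least 1.7-fold lower number from compound 1 to compound 2 (0.24 log units; that floor lies within the scatter), and it exchanges one group on an amine nitrogen. Among the measured compounds shown here, its true size remains unknown, and it is the only guide available here.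

The next compound to be measured is compound 3 `Cc1cc(C)cc(NC(=O)NCCNS(=O)(=O)c2ccc(-c3ccccc3OCc3ccccc3)s2)c1`, which changes the same place: a group of 11 heavy atoms (9 carbon, 1 nitrogen, 1 oxygen; one six-membered aromatic ring of carbon only) in place of a group of 12 heavy atoms (7 carbon, 2 nitrogen, 2 oxygen, 1 sulfur; one six-membered aromatic ring of carbon only), on an amine nitrogen. The entering group, (3,5-dimethylphenyl)carbamoyl, holds no sulfur, and neither does the matching group in compound 1. The expectation therefore leans a little towards compound 1, with an at least 1.7-fold lower number from compound 1 to compound 2 (0.24 log units; that floor lies within the scatter) as the only measure of size. The expected change is a 1.4-fold higher number from compound 2 to compound 3 (0.15 log units; within the scatter), a small move towards a higher number that is not expected to exceed the scatter. A reading that reports only a limit is also quite possible. The estimate for compound 3 is 16000 nM, with an expected range from 7000 nM to 35000 nM.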

Compound 3, half-maximal inhibitory concentration: > 50000 nM
Compound 3: no number, only a limit (the forecaster's own chance of this, stated with the estimate: 45%); middle value at least 3.1-fold (0.49 log units) away from the limit.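

At this place, on an amine nitrogen, this assay now shows a change that clears the scatter: an at least 4.4-fold higher number from compound 2 to compound 3 (0.64 log units; beyond the scatter), whereas the earlier step had only a floor lying within the scatter. Compound 1 and compound 3, the two of the three compounds without sulfur in this group, both read as limits of the assay and not as numbers, and the step between them cannot be read. The reading for compound 3 is such a limit, so its step from compound 2 has a floor and no known full size: the limit of > 50000 nM in this assay, at which 1 of the 3 values shown sits.

The step from compound 2 changes the sulfur and the substituents on the aromatic ring together, and the compounds shown do not separate these two changes. Within the data shown here, also open is whether an amine or a carboxylic acid on that aromatic ring, or a longer chain in place of the saturated chain on the amine nitrogen, would give a number lower than the one compound 2 gives, 11300 nM.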